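The compounds below may be only part of what the source reports. "The series", "measured", "known", "first", "only" and "open" are said of these compounds alone.

Compound 1, `O=C(COc1ccc(C(=O)/C=C/c2ccc(Cl)cc2Cl)cc1)N[C@H]1CCOC1=O`, gives 8040 nM in a functional assay on PC-3 cells (Homo sapiens) for antiproliferative activity, read by MTT assay, with a stated time of 72 h; on this read-out lower numbers stand for stronger inhibition and higher numbers for weaker inhibition.
Compound 2, `O=C1OCC[C@@H]1NC(=S)SCCOc1cccc2ccccc12`, gives in this assay only a limit, > 64000 nM.
Compound 3, `O=C(CNc1cccc(Cl)c1)N[C@H]1CCOC1=O`, gives in this assay likewise only a limit, > 64000 nM.

Among these three results compound 1 stands alone as the only measured number; the other two results are limits and not numbers, since they sit at the limit of > 64000 nM in this assay, at which 2 of the 3 values shown sit. Among the measured compounds shown here, no pair of the measured compounds differs in a single place, so no measured step can be drawn between them; all that can be said is that compound 1 yields a number while compound 2 and compound 3 do not.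

Compound 4, `O=C(COc1ccc(C(=O)/C=C/c2cccc([N+](=O)[O-])c2)cc1)N[C@H]1CCOC1=O`, has not yet been measured. It shares the core of compound 1 and differs from it in one place: 3-nitrophenyl in place of 2,4-dichlorophenyl on a double-bonded chain carbon bound to a double-bonded chain carbon. No measured step of this kind is shown, so the expectation rests on compound 1 alone, which gives 8040 nM in this assay. The step of a 1.5-fold higher number from compound 1 to compound 4 (0.17 log units; within the scatter) is expected to be small, at most a modest loss that may lie within the usual scatter. Compound 4 is therefore estimated at 12000 nM in this assay, with a range from 3500 nM to 45000 nM.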

Compound 4, half-maximal inhibitory concentration: 56300 nM
Compound 4: the middle estimate sits 4.7-fold (0.67 log units) below what was measured; the measured number lies above the stated range.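

Putting 3-nitrophenyl in place of 2,4-dichlorophenyl on a double-bonded chain carbon bound to a double-bonded chain carbon gives a 7.0-fold higher number from compound 1 to compound 4 (0.85 log units; beyond the scatter), so what this position carries is not indifferent in this assay. Among the compounds shown here, this is the first step that can be read, and it shows that the shared core alone does not set the number of compound 1, since the group at this place moves it beyond the scatter. Compound 4 still gives a number rather than a limit, but that number lies close to the top of what is reported for the series: the limit of > 64000 nM in this assay, at which 2 of the 4 values shown sit.

A single step cannot tell whether the loss follows from the departure of the 2,4-dichlorophenyl group or from the arrival of the 3-nitrophenyl group, and it cannot tell which of the two chlorines, if either, counts. On these data alone, an unsubstituted phenyl, a 4-chlorophenyl or a 4-methoxyphenyl at the same place would begin to separate these readings, and whether any group here can take the number lower than that of compound 1 remains open.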